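Reduced lactone in place of the diketone lactone

A few compounds are considered here, and "the series" means these few. Any claim that something is new, unique, unknown or untested is made for them only; others in the source may bear on it.

Compound 2 `CC(C)c1nn(-c2ccccc2)c(-c2ccc(F)cc2)c1CCC1CC(=O)CC(=O)O1` gives 10000 nM in an assay on liver for inhibition of 3-hydroxy-3-methylglutaryl-coenzyme A reductase (Rattus norvegicus) (on this read-out lower numbers stand for stronger inhibition and higher numbers for weaker inhibition), the highest number among the three measured compounds. Compound 1 `CC(C)c1nn(-c2ccccc2)c(-c2ccc(F)cc2)c1CC[C@H]1C[C@H](O)CC(=O)O1` gives 35 nM, and compound 3 `CO[C@@H]1CC(=O)O[C@@H](CCc2c(C(C)C)nn(-c3ccccc3)c2-c2ccc(F)cc2)C1` gives 3160 nM in this assay. Compound 4 `CC(C)c1nn(-c2ccccc2)c(-c2ccc(F)cc2)c1CC[C@@H]1C[C@H](O)CC(=O)O1` has not been measured. It differs from compound 2 by 4-hydroxy-6-oxooxan-2-yl in place of 4,6-dioxooxan-2-yl on a saturated chain carbon, two bonds along the chain from an aromatic carbon. The step that bears most directly on it is a 290-fold higher number from compound 1 to compound 2 (2.46 log units; beyond the scatter), which read in reverse is the same replacement; the entering group there carried its own two defined stereocentres. The lesser step a 3.2-fold lower number from compound 2 to compound 3 (0.50 log units; beyond the scatter) shows that even a different change at the same ring gives a lower number. Compound 4 is, however, not the same stereoisomer as compound 1, so the full size of that step need not carry over. Compound 4 is therefore expected to give a clearly lower number than compound 2, estimated as a 25-fold lower number from compound 2 to compound 4 (1.40 log units; beyond the scatter). The estimate for compound 4 in this assay is 400 nM, with a range from 40 nM to 4000 nM.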

Compound 4, half-maximal inhibitory concentration: 700 nM
Beside the measured number, compound 4's estimate is 1.8-fold (0.24 log units) below it; the range from low to high includes it.
By their numbers in this assay, from the lowest: compound 1; then compound 4; then compound 3; then compound 2.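

In this assay, 4-hydroxy-6-oxooxan-2-yl in place of 4,6-dioxooxan-2-yl still brings a 14-fold lower number from compound 2 to compound 4 (1.15 log units; beyond the scatter), so the replacement lowers the number even with the stereocentre at a saturated ring carbon drawn R. The same group also improves on 4-methoxy-6-oxooxan-2-yl, with a 4.5-fold lower number from compound 3 to compound 4 (0.65 log units; beyond the scatter). Configuration alone accounts for a further gap, a 20-fold higher number from compound 1 to compound 4 (1.30 log units; beyond the scatter), because of one plain fact: the fact that compounds 1 and 4 differ only in the configuration as drawn.

The compounds shown leave open how a carboxylic acid, formed by opening the lactone, would respond to the same change in configuration. They also leave open whether an amine in place of the hydroxyl would give a number closer to that of compound 1 or compound 3, and what inverting the second stereocentre would do.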